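Anilino to (phenylsulfonyl)amino on a shared core

A few compounds are considered here, and "the series" means these few. Any claim that something is new, unique, unknown or untested is made for them only; others in the source may bear on it.

Compound 1 `O=C1Nc2ccc(S(=O)(=O)N3CCOCC3)cc2/C1=N/c1ccc(Br)cc1`: 372000 nM
Compound 2 `O=C1Nc2ccc(S(=O)(=O)N3CCOCC3)cc2/C1=N/Nc1ccccc1`: 262000 nM

Within the data shown here, in an ADME assay on WI-38 cells (Homo sapiens) for cytotoxicity, read by sulforhodamine B assay, with a stated time of 24 h (a lower number here means a stronger inhibitor, a higher number a weaker inhibitor), compound 2 gives 262000 nM, which lies within the scatter of the only other measured compound, compound 1, so the two cannot be ranked.

Compound 3 `O=C1Nc2ccc(S(=O)(=O)N3CCOCC3)cc2/C1=N/NS(=O)(=O)c1ccccc1` keeps the core of compound 2 and alters one group: phenylsulfonyl in place of phenyl on an amine nitrogen. The counted difference is phenylsulfonyl in place of phenyl on an amine nitrogen.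

Among the measured compounds shown here, only one measured step bears on this, and only loosely: a 1.4-fold lower number from compound 1 to compound 2 (0.15 log units; within the scatter). That step concerned a different exchange, anilino in place of 4-bromophenyl on a double-bonded nitrogen. For the measured compounds named here, no measured pair of compounds tests the phenylsulfonyl group itself. With so little evidence, no shift beyond the scatter is expected in this assay, in either direction, and the uncertainty stays wide.

The estimated step is a 1.1-fold higher number from compound 2 to compound 3 (0.03 log units; within the scatter).

For compound 3 the estimated value is 280000 nM, with an expected range from 120000 nM to 600000 nM.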

Compound 3, half-maximal inhibitory concentration: 302000 nM
For compound 3 the middle estimate is 1.1-fold (0.03 log units) below the measured one, and the stated range covers the measured number.
By their numbers in this assay, from the lowest: compounds 2, 3 and 1 (each within the scatter of the next).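

In this assay, putting phenylsulfonyl in place of phenyl on the amine nitrogen gives a 1.2-fold higher number from compound 2 to compound 3 (0.06 log units; within the scatter) and so adds a sulfonyl unit, with its hydrogen-bond acceptors, without a readable shift in the number. Exchanging 4-bromophenyl on the double-bonded nitrogen for (phenylsulfonyl)amino gives a 1.2-fold lower number from compound 1 to compound 3 (0.09 log units; within the scatter) and shows the same thing from a second direction, so the three groups tried at this place cannot be ranked against one another in this cell test. Nothing measured here offers an explanation for how closely these numbers sit together.

On these data alone, all three groups carry a six-membered aromatic ring of carbon, so it remains open whether a group without such a ring, such as a simple amine, a carboxylic acid or a longer alkyl chain, would move the number beyond the scatter. Also open, as far as these compounds go, is whether a methoxy group or a nitrile added to the phenyl ring of the phenylsulfonyl group would leave the number just as unmoved.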